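The source may report more compounds than this note shows. Statements on the series, on what has been measured and on what is new or still open speak of the compounds shown alone.

Compound 1 `c1ccc(-c2ccc(Cn3cncc3CNc3cccc(-c4ccccc4)c3)cc2)cc1`: 10000 nM
Compound 2 `c1ccc(-c2ccc(Cn3cncc3CNc3ccc(-c4ccccc4)c(-c4ccccc4)c3)cc2)cc1`: > 10000 nM
Compound 3 `c1ccc(-c2ccc(Cn3cncc3CNc3ccc(-c4cncs4)c(-c4ccccc4)c3)cc2)cc1`: > 1000 nM

In a toxicity assay on NIH3T3 cells (Mus musculus) for cytotoxicity, read by resazurin assay (a higher number here means that more compound is needed for the effect, a lower number that less compound is needed), compound 3 gives > 1000 nM, which is a limit and not a number. Compound 2 also stands at a limit, > 10000 nM. Only compound 1 gives a number, 10000 nM.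

Compound 4 `c1ccc(-c2ccc(Cn3cncc3CNc3ccc(-c4nc5ccccc5o4)c(-c4ccccc4)c3)cc2)cc1` differs from compound 3 by one change on an aromatic carbon: 1,3-benzoxazol-2-yl in place of 1,3-thiazol-5-yl on an aromatic carbon.

Among the measured compounds shown here, three measured steps bear on this place: a number no lower from compound 1 to compound 2 (the limit leaves the size open), a step that the limit leaves unreadable from compound 1 to compound 3 and a step that the two limits leave unreadable from compound 2 to compound 3. None of them has a readable size, so they give no direction for the change. The step expected in this assay is therefore a step that the limit leaves unreadable from compound 3 to compound 4, and it is only a rough expectation. For compound 4 the estimated value is 6000 nM, with an expected range from 1500 nM to 20000 nM.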

Compound 4, half-maximal effective concentration: > 10000 nM
Compound 4 was reported as a limit; the forecaster's own chance of this, stated with the estimate: 70%; at least 1.6-fold (0.22 log units) between middle value and limit.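

With 1,3-benzoxazol-2-yl at this place, para to a large group, this assay shows a number no lower from compound 1 to compound 4 (the limit leaves the size open). Compound 4 gives > 10000 nM, which is a limit and not a number, so a fused bicyclic group here, like phenyl in compound 2, brings no readable value. The steps linking compound 4 to compound 2 and compound 3 cannot be read, and the shared limit is all that stands: the limit of > 10000 nM in this assay, at which 2 of the 4 values shown sit.

From the compounds shown here alone, how far these compounds lie past their limits stays open. So does whether an amine or a carboxylic acid on this aromatic carbon would give a readable number in this assay.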